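Series notes: from compound 3 to compound 4

The source may hold more compounds than are shown below. What is called first, only, known or untested is meant among the compounds shown, and "the series" means these compounds.

Compound 3 `O=C(Nc1ccc(-n2ncc3ccccc32)cc1)Nc1ccc(Cl)c(C(F)(F)F)c1` carries the shared core without any halogen on its fused ring. For the measured compounds named here, in a functional assay on A549 cells (Homo sapiens) for cytotoxicity, read by MTT assay, with a stated time of 72 h (a higher number here means a weaker inhibitor, a lower number a stronger inhibitor), compound 3 gives 9900 nM, the highest of the three numbers measured so far. Compound 1 `O=C(Nc1ccc(-n2ncc3c(Cl)cccc32)cc1)Nc1ccc(Cl)c(C(F)(F)F)c1` gives 3100 nM and compound 2 `O=C(Nc1ccc(-n2ncc3c(Br)cccc32)cc1)Nc1ccc(Cl)c(C(F)(F)F)c1` gives 2300 nM; the step of a 3.2-fold higher number from compound 1 to compound 3 (0.50 log units; beyond the scatter) and the step of a 4.3-fold higher number from compound 2 to compound 3 (0.63 log units; beyond the scatter) both lie beyond the scatter, while a 1.3-fold lower number from compound 1 to compound 2 (0.13 log units; within the scatter) does not. Compound 4 `O=C(Nc1ccc(-n2ncc3cccnc32)cc1)Nc1ccc(Cl)c(C(F)(F)F)c1` differs from compound 3 by a group of 9 heavy atoms (6 carbon, 3 nitrogen; one five-membered aromatic ring with 2 hetero atoms, one six-membered aromatic ring with 1 hetero atom) in place of a group of 9 heavy atoms (7 carbon, 2 nitrogen; one five-membered aromatic ring with 2 hetero atoms, one six-membered aromatic ring of carbon only), on an aromatic carbon. Going by the values given here, none of the measured steps bears on this change; all of them concern a halogen on the six-membered aromatic ring of carbon only, which compound 3 does not carry. The expectation is therefore no step beyond the scatter, no change at the digits printed from compound 3 to compound 4 (within the scatter). Compound 4 is estimated at 9900 nM, within a range from 4000 nM to 25000 nM.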

Compound 4, half-maximal inhibitory concentration: > 32000 nM
Compound 4 gave a limit, no number (the forecaster's own chance of this, stated with the estimate: 10%); middle value at least 3.2-fold (0.50 log units) away from the limit.
By their numbers in this assay, from the lowest: compounds 2 and 1 (each within the scatter of the next); then compound 3. At a limit, above all of these: compound 4.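

In this assay compound 4 gives only a limit, not a number: the limit of > 32000 nM in this assay, at which 1 of the 4 values shown sits. Earlier steps changed only a halogen on the six-membered aromatic ring of carbon only, whereas this one puts a hetero atom into that ring and gives an at least 3.2-fold higher number from compound 3 to compound 4 (0.50 log units; beyond the scatter), so the ring itself, not just its halogen, matters to this read-out. Against the halogen-bearing compounds the gaps are wider: an at least 13-fold higher number from compound 2 to compound 4 (1.14 log units; beyond the scatter) and an at least 10-fold higher number from compound 1 to compound 4 (1.01 log units; beyond the scatter).

From the compounds shown here alone, whether chloro or bromo would lower the number on the six-membered aromatic ring with 1 hetero atom stays open. So does how an amine or a methoxy group would read in the halogen's place.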